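Trimming the Aryl Ether to an Ethyl Group

This account rests on a few compounds, and the source may have more. Where it says the series, first, only, none or still open, it means among the compounds named here.

Compound 2 `CC(Nc1ccccc1Oc1ccc(N)cc1)=C1C(=O)CC(c2ccccc2)CC1=O` and compound 1 `COc1cc(Oc2ccccc2NC(C)=C2C(=O)CC(c3ccccc3)CC2=O)ccc1N` share the same core and differ only by hydrogen in place of methoxy on an aromatic carbon. In a functional assay on CCRF-CEM cells (Homo sapiens) for antiproliferative activity, read by cell counting, with a stated time of 96 h (on this read-out higher numbers stand for weaker inhibition and lower numbers for stronger inhibition), compound 1 gives 12 nM, and compound 2 gives 37 nM; the step of a 3.1-fold higher number from compound 1 to compound 2 (0.49 log units; beyond the scatter) lies beyond the scatter. Going by the values given here, compound 2 therefore stands at the higher of the two numbers measured so far, the weaker of the pair.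

Compound 3 `CCOc1ccccc1NC(C)=C1C(=O)CC(c2ccccc2)CC1=O` differs from compound 2 by ethyl in place of 4-aminophenyl on an oxygen on an aromatic ring. Among the compounds with values here, no measured step bears directly on this change: the single step measured concerns the methoxy group, not the substituent on the aryl oxygen, so the values of compound 1 and compound 2 only show the range in which this core has been found. Replacing 4-aminophenyl by ethyl is a larger change than anything measured here, and its direction cannot be read from the data. Compound 3 is nonetheless expected to show a step of a 4.1-fold higher number from compound 2 to compound 3 (0.61 log units; beyond the scatter), toward a higher number, with wide uncertainty. The estimate for compound 3 in this assay is 150 nM, in the range 30 nM to 1000 nM.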

Compound 3, half-maximal inhibitory concentration: 190 nM
Compound 3: the middle estimate sits 1.3-fold (0.10 log units) below what was measured; the measured number falls inside the stated range.
By their numbers in this assay, from the lowest: compound 1; then compound 2; then compound 3.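

The group on the oxygen on an aromatic ring turns out to matter in this assay: ethyl in place of 4-aminophenyl gives a 5.1-fold higher number from compound 2 to compound 3 (0.71 log units; beyond the scatter), a larger step than the earlier methoxy change, and ethyl in place of 4-amino-3-methoxyphenyl gives a 16-fold higher number from compound 1 to compound 3 (1.20 log units; beyond the scatter), which is large. The aromatic group is therefore not indispensable, since compound 3, with only ethyl there, still gives 190 nM, yet compound 3 has the highest number of the three and both larger groups stand well below it. No evidence is available on why this replacement raises the number.

The step removes the ring and its amino group together, so the compounds shown leave open how much of the change belongs to each. A plain phenyl on that oxygen would separate the two, and a longer chain ending in an amine would show whether the amine can act without the ring.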